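A few compounds are considered here, and "the series" means these few. Any claim that something is new, unique, unknown or untested is made for them only; others in the source may bear on it.

Measured so far in an ADME assay on HUVEC cells (Homo sapiens) for cytotoxicity, read by MTT assay, with a stated time of 24 h; a lower number here means that less compound is tolerated, a higher number that more compound is tolerated:
compound 1 `Brc1cccc(/C=C/c2nnc(-c3ccc4c(c3)OCCO4)o2)c1`: 322000 nM
compound 2 `O=[N+]([O-])c1ccc(/C=C/c2nnc(-c3ccc4c(c3)OCCO4)o2)cc1`: 299000 nM
compound 3 `COc1ccc(/C=C/c2nnc(-c3ccc4c(c3)OCCO4)o2)cc1`: 312000 nM

Compound 3 lies within the scatter of both other compounds, so the three values stand as one group without an order. Next is compound 4 `COc1cccc(/C=C/c2nnc(-c3ccc4c(c3)OCCO4)o2)c1`, with the change 3-methoxyphenyl in place of 4-methoxyphenyl on a double-bonded chain carbon bound to a double-bonded chain carbon. Going by the values given here, two measured steps bear on this. The step of a 1.0-fold lower number from compound 1 to compound 3 (0.01 log units; within the scatter) swaps the group at the same place, and the step of a 1.0-fold higher number from compound 2 to compound 3 (0.02 log units; within the scatter) swaps a group on that aromatic ring. Among the compounds with values here, no measured step isolates this exact swap, but neither step leaves the scatter, so no shift beyond it is expected in this assay. The expected step is a 1.0-fold lower number from compound 3 to compound 4 (0.00 log units; within the scatter). Compound 4 is estimated at 310000 nM, with an expected range of 200000 nM to 450000 nM.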

Compound 4, half-maximal cytotoxic concentration: 332000 nM
For compound 4 the middle estimate is 1.1-fold (0.03 log units) below the measured one; the range from low to high includes it.
By their numbers in this assay, from the lowest: compounds 2, 3, 1 and 4 (each within the scatter of the next).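

In this assay, 3-methoxyphenyl in place of 4-methoxyphenyl on a double-bonded chain carbon gives a 1.1-fold higher number from compound 3 to compound 4 (0.03 log units; within the scatter), so this swap of the methoxyphenyl isomers, not covered by an earlier step, leaves the number within the scatter. Methoxy in place of bromo on an aromatic carbon gives a 1.0-fold higher number from compound 1 to compound 4 (0.01 log units; within the scatter), which also stays within the scatter. No measurement on hand accounts for these small steps.

As far as these compounds go, whether an amine or a carboxylic acid on this phenyl ring would produce a step beyond the scatter remains open. From the compounds shown here alone, the effect of changing the shared core also remains open.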